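A few compounds are considered here, and "the series" means these few. Any claim that something is new, unique, unknown or untested is made for them only; others in the source may bear on it.

Compound 1 `O=C(NO)c1ccc(Cl)c(NC(=O)c2ccc(-c3ccccc3)cc2)c1`: in an ADME assay on isolated protein for inhibition of protein deacetylase HDAC6 (Homo sapiens), read by fluorescence, with a stated time of 90 min (a higher number here means a weaker inhibitor, a lower number a stronger inhibitor), compound 1 gives 160 nM.
Compound 2 `O=C(NO)c1ccc(Cl)c(NC(=O)c2ccc(-c3ccccc3)cc2Cl)c1`: compound 2 gives 2400 nM.
Compound 3 `CCOc1ccc(C(C)=O)cc1NC(=O)c1cccc(C(=O)NO)c1`: compound 3 gives 120 nM.

Compound 2 differs from compound 1 by chloro in place of hydrogen on an aromatic carbon, and this change made the step of a 15-fold higher number from compound 1 to compound 2 (1.18 log units; beyond the scatter). Compound 4 `CCOc1ccc(C(C)=O)cc1NC(=O)c1cc(C(=O)NO)ccc1Cl`, not yet measured, differs from compound 3 by chloro in place of hydrogen on an aromatic carbon, the same kind of change, though the surroundings are not identical: in compound 2 the new chloro is meta to a phenyl group, in compound 4 it is para to a hydroxycarbamoyl group. The difference between the cores of compound 1 and compound 3 is not broken down here. Since the one measured case of this change weakened inhibition, a rise of similar kind is expected from compound 3 to compound 4 in this assay, a 10-fold higher number from compound 3 to compound 4 (1.00 log units; beyond the scatter), resting on a 15-fold higher number from compound 1 to compound 2 (1.18 log units; beyond the scatter) and the different core. Compound 4 is thus estimated at 1200 nM, between 400 nM and 4000 nM.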

Compound 4, half-maximal inhibitory concentration: 110 nM
Compound 4: middle estimate off by 11-fold (1.04 log units), on the high side, outside the stated range (below it).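

In this assay, the new measurement gives a 1.1-fold lower number from compound 3 to compound 4 (0.04 log units; within the scatter), so on this core the chloro leaves the number within the scatter. On the other core, the same change weakened inhibition, and the two steps differ by more than repeated measurements would explain: the same change on two cores in this assay, a 15-fold higher number (1.18 log units; beyond the scatter) from compound 1 to compound 2 and a 1.1-fold lower number (0.04 log units; within the scatter) from compound 3 to compound 4, 16-fold (1.21 log units) apart, beyond the scatter of two such steps. This shows that the size of the step did not carry from one core to the other, but two pairs do not show which difference between the cores matters or what a further core would do.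

The compounds shown leave open how a fluoro or a methyl group in place of the same hydrogen would behave on either core. They also leave open whether an amine there would follow the chloro on either core.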